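Swapping iodo for fluoro on the aromatic ring

The compounds below may be only part of what the source reports. "The series", "measured", "known", "first", "only" and "open" are said of these compounds alone.

- Compound 1 `CC(=NNC(=S)Nc1cccc(F)c1)c1ccccn1` gives 9 nM
- Compound 2 `C/C(=N/NC(=S)Nc1cccc(I)c1)c1ccccn1` gives 45 nM

Both values come from a functional assay on MCF7 cells (Homo sapiens) for cytotoxicity, read by MTT assay, with a stated time of 48 h (on this read-out higher numbers stand for weaker inhibition and lower numbers for stronger inhibition), and can be compared directly. Compound 2 has the higher of the two numbers, and its gap to compound 1 lies beyond the scatter of repeated measurements. Compound 2 is therefore the weaker inhibitor of this pair.

Compound 3 `C/C(=N/NC(=S)Nc1cccc(F)c1)c1ccccn1` has not been measured yet. It differs from compound 2 by one exchange, fluoro in place of iodo on an aromatic carbon with fluoro in place of iodo on an aromatic carbon. Within the data shown here, no measured pair shows this exchange on its own, so the data offer only an indirect guide. That guide is compound 1, which also carries fluoro and gives 9 nM in this assay as its result. A drop beyond the scatter, towards stronger inhibition, is expected for the step of a 4.5-fold lower number from compound 2 to compound 3 (0.65 log units; beyond the scatter) on this basis. For compound 3 the estimated value is 10 nM with a range from 4.5 nM to 22 nM as the expected spread.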

Compound 3, half-maximal inhibitory concentration: 9 nM
The estimate for compound 3 lay 1.1-fold (0.05 log units) above the measured number, and the stated range covers the measured number.
By their numbers in this assay, from the lowest: compounds 1 and 3 (each within the scatter of the next); then compound 2.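

In this assay, fluoro in place of iodo on an aromatic carbon can now be read as a single change, since compound 2 and compound 3 are drawn alike everywhere else, and it gives a 5.0-fold lower number from compound 2 to compound 3 (0.70 log units; beyond the scatter). Compound 1 could not show this alone, as it differs from compound 2 in its halogen and also in how its double bond is drawn. The second comparison gives no change at the digits printed from compound 1 to compound 3 (within the scatter), and only one thing separates that pair: the fact that one of compounds 1 and 3 is drawn with a defined configuration and the other without, at the place where they differ

The drawings leave open whether compound 1 and compound 3 are the same form in the test, and how the opposite configuration at the double bond would read. Going by these compounds, with only fluoro and iodo at this place on the ring, it also remains open how chloro, bromo, a methoxy group or an amine would fall, and whether the numbers would follow any order across such groups.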